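Swapping chloro for methyl on the benzyl ring

The source may report more compounds than this note shows. Statements on the series, on what has been measured and on what is new or still open speak of the compounds shown alone.

Compound 3 `O=C(NC1CCN(Cc2ccc(Cl)cc2)CC1)c1ccc2ccccc2c1` belongs to a small set of amides in which a naphthalene carbonyl is joined through a piperidine to a substituted benzyl group. In an assay on isolated protein for displacement of a labelled ligand from D(4) dopamine receptor (Homo sapiens) (a higher number here means a weaker inhibitor, a lower number a stronger inhibitor), compound 3 gives 37 nM. Among the compounds with values here, that is the lowest of the three numbers measured so far, though the gaps are small: compound 1 `O=C(NC1CCN(Cc2cccc(Br)c2)CC1)c1cccc2ccccc12` gives 66 nM and compound 2 `Cc1ccc(CN2CCC(NC(=O)c3cccc4ccccc34)CC2)cc1` gives 69 nM, and both differences to compound 3 fall within the usual scatter, so the three cannot really be told apart.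

Compound 4 `Cc1ccc(CN2CCC(NC(=O)c3ccc4ccccc4c3)CC2)cc1` is reached from compound 3 by a single change: methyl in place of chloro on an aromatic carbon. One measured step speaks to this kind of exchange. From compound 1 to compound 2 a 3-bromophenyl became a 4-methylphenyl on the same benzyl position, and the result was a 1.0-fold higher number from compound 1 to compound 2 (0.02 log units; within the scatter). A halogen on the benzyl ring was replaced by a methyl there without a shift beyond the scatter.

By that precedent the change from compound 3 to compound 4 is expected to be a 1.1-fold higher number from compound 3 to compound 4 (0.06 log units; within the scatter). For compound 4 in this assay the estimate is therefore 42 nM, with a likely range from 15 nM to 120 nM.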

Compound 4, inhibition constant: 21 nM
Compound 4: the middle estimate sits 2.0-fold (0.30 log units) above what was measured, within the range that was stated.
By their numbers in this assay, from the lowest: compounds 4, 3, 1 and 2 (each within the scatter of the next, the first and the last beyond it).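

Within the data shown here, this is the first direct look at the position named in 4-chlorophenyl to 4-methylphenyl, since the one earlier step moved the substituent's place on the ring as well as changing the group, whereas here only the group changes and its place stays fixed. In this assay the exchange gives a 1.8-fold lower number from compound 3 to compound 4 (0.25 log units; within the scatter) and so lies within the scatter, which means that chloro and methyl at this spot cannot be told apart, and the ordering of the two printed numbers should not be read as a real gain. Taken with the earlier step, two halogen-to-methyl exchanges on the benzyl ring now leave the number within the scatter, though no measurement shown here explains why these groups read alike.

The compounds shown span only chloro, bromo and methyl on this ring, all single-atom groups, so it remains open whether a larger or very different group at the same place, such as a methoxy group, an amine, a carboxylic acid or a longer chain, would move the number beyond the scatter. From the compounds shown here alone, the ring with plain hydrogen at this position is also absent from the set, so the effect of having any substituent there at all remains unknown.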